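Benzylamino nucleosides with varied aryl groups against HOS cells

The compounds below may be only part of what the source reports. "The series", "measured", "known", "first", "only" and "open" are said of these compounds alone.

Compound 1, `COc1cccc(CNc2ncnc3c2ncn3[C@@H]2O[C@H](CO)[C@@H](O)[C@H]2O)c1OC`, gives > 166000 nM in a functional assay on HOS cells (Homo sapiens) for antiproliferative activity, with a stated time of 72 h; on this read-out higher numbers stand for weaker inhibition and lower numbers for stronger inhibition.
Compound 2, `COc1ccc(CNc2ncnc3c2ncn3[C@@H]2O[C@H](CO)[C@@H](O)[C@H]2O)c(OC)c1`, gives > 166000 nM in this assay.
Compound 3, `COc1cc(CNc2ncnc3c2ncn3[C@@H]2O[C@H](CO)[C@@H](O)[C@H]2O)cc(OC)c1`, is recorded as "not determined" (no result reported) in this assay, with no result reported.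

The value for compound 1 is a limit of the assay and not a number. The value for compound 2 is likewise a limit. The step that the two limits leave unreadable from compound 1 to compound 2 therefore cannot be read, as the limit of > 166000 nM in this assay, at which 2 of the 3 values shown sit, shows. Compound 3 stands among the numbers shown only by structure: its shared core matches compound 1 and compound 2, and it carries a 3,5-dimethoxyphenyl on a saturated chain carbon bound to a nitrogen on an aromatic ring, but no measurement of it in this assay is available.

Compound 4, `OC[C@H]1O[C@@H](n2cnc3c(NCc4ccc(C(F)(F)F)cc4)ncnc32)[C@H](O)[C@@H]1O`, differs from compound 3 as follows: 4-(trifluoromethyl)phenyl in place of 3,5-dimethoxyphenyl on a saturated chain carbon bound to a nitrogen on an aromatic ring. Among the compounds with values here, no measured step bears directly on this change, and the single step that exists is unreadable. With both measured relatives sitting at the limit, compound 4 is expected to show weak inhibition as well, most likely again reported only as a limit, and its estimate in this assay is 150000 nM, within a range from 30000 nM to 500000 nM.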

Compound 4, half-maximal inhibitory concentration: > 166000 nM
Compound 4 was reported as a limit; the forecaster's own chance of this, stated with the estimate: 70%; at least 1.1-fold (0.04 log units) between middle value and limit.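

Compound 4, like compound 1 and compound 2, is reported only as a limit of the assay and not as a number, so none of the steps among these three compounds can be read: the limit of > 166000 nM in this assay, at which 3 of the 4 values shown sit.

The compounds shown leave open whether changing the aryl group on the shared core alters inhibition in this assay at all.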